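Two Aryl Groups on an Amine Nitrogen in Rat Aorta

This account rests on a few compounds, and the source may have more. Where it says the series, first, only, none or still open, it means among the compounds named here.

Compound 1 `C/N=C(\NC#N)N[C@@H]1c2cc(C#N)ccc2OC(C)(C)[C@H]1O`: 200 nM
Compound 2 `CC1(C)Oc2ccc(C#N)cc2[C@@H](/N=C(\NC#N)Nc2cccc(C(F)(F)F)c2)[C@@H]1O`: 1600 nM

In a functional assay (aorta) with Rattus norvegicus as the target (a higher number here means a weaker inhibitor, a lower number a stronger inhibitor), compound 1 gives 200 nM, while compound 2 gives 1600 nM, the highest of the two numbers and beyond the scatter from compound 1. Compound 3 `Cc1ccc(N/C(=N/[C@@H]2c3cc(C#N)ccc3OC(C)(C)[C@H]2O)NC#N)cc1` differs from compound 2 in one place: 4-methylphenyl in place of 3-(trifluoromethyl)phenyl on an amine nitrogen. One six-membered aromatic ring replaces another on the same nitrogen, so compound 3 is expected to stay near compound 2, with the step of a 1.6-fold lower number from compound 2 to compound 3 (0.20 log units; within the scatter) estimated as small, perhaps toward a lower number but likely within the scatter. Compound 3 is expected to give 1000 nM in this assay, with a range from 300 nM to 4000 nM.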

Compound 3, half-maximal inhibitory concentration: 2700 nM
Compound 3: middle estimate off by 2.7-fold (0.43 log units), on the low side, and the stated range covers the measured number.
By their numbers in this assay, from the lowest: compound 1; then compounds 2 and 3 (each within the scatter of the next).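

In this assay, 4-methylphenyl in place of 3-(trifluoromethyl)phenyl on the amine nitrogen gives a 1.7-fold higher number from compound 2 to compound 3 (0.23 log units; within the scatter). This position therefore accepts one substituted six-membered aromatic ring in place of another with no difference that stands out from the scatter. No evidence on the reason for this outcome is available.

The compounds shown leave open how a pyridine ring or a benzyl group would read on this nitrogen. Going by these compounds, since the substituent and its place on the ring change together here, the contribution of each also remains open.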